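The compounds below may be only part of what the source reports. "The series", "measured", "known", "first", "only" and "open" are said of these compounds alone.

Measured compounds in an ADME assay on Huh-5-2 cells (Homo sapiens) for cytotoxicity, with a stated time of 3 days; a lower number here means that less compound is tolerated, a higher number that more compound is tolerated:

Compound 1 `CCOC(=O)c1csc([C@H]2[C@@H](COC)C[C@@](CC(C)C)(C(=O)O)N2C(=O)c2ccc(C(C)(C)C)c(OC)c2)n1` gives 200000 nM in this assay.
Compound 2 `COC[C@H]1C[C@@](CC(C)C)(C(=O)O)N(C(=O)c2ccc(C(C)(C)C)c(OC)c2)[C@H]1[C@H]1COC(=O)O1` reaches only a limit of this assay, > 120000 nM.
Compound 3 `COC[C@H]1C[C@@](CC(C)C)(C(=O)O)N(C(=O)c2ccc(C(C)(C)C)c(OC)c2)[C@H]1COC` likewise reaches only a limit, > 120000 nM.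

Compound 3 therefore stands on a limit and not on a number, and of the other two values one more is a limit (the limit of > 120000 nM in this assay, at which 2 of the 3 values shown sit), so compound 3 cannot be placed above or below either neighbour. The three measured steps are all unreadable: a step that the limit leaves unreadable from compound 1 to compound 2, a step that the limit leaves unreadable from compound 1 to compound 3 and a step that the two limits leave unreadable from compound 2 to compound 3. All three replace the same group on the same saturated ring carbon, but none gives a size.

Compound 4 `COC[C@H]1C[C@@](CC(C)C)(C(=O)O)N(C(=O)c2ccc(C(C)(C)C)c(OC)c2)[C@H]1C(=O)OC` differs from compound 3 by methoxycarbonyl in place of methoxymethyl on a saturated ring carbon. The replacement again sits on that saturated ring carbon, in the position every measured step has already varied. With no readable step to draw on, no shift beyond the scatter is expected, and compound 4 is expected at 150000 nM (range 90000 nM to 250000 nM), the expected step being a step that the limit leaves unreadable from compound 3 to compound 4, most likely reported as a limit again.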

Compound 4, half-maximal cytotoxic concentration: > 120000 nM
Compound 4: a limit, no number; the forecaster's own chance of this, stated with the estimate: 70%; the middle value does not contradict the limit.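

Compound 4 stands on a limit, and no step to it from compound 1, compound 2 or compound 3 can be read in this assay: the limit of > 120000 nM in this assay, at which 3 of the 4 values shown sit.

Whether any group on that saturated ring carbon shifts the tolerated concentration, and in which direction, stays open among the compounds shown.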